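Replacing methoxy with chloro in compound 1

A few compounds are considered here, and "the series" means these few. Any claim that something is new, unique, unknown or untested is made for them only; others in the source may bear on it.

For the measured compounds named here, in a functional assay on MCF7 cells (Homo sapiens) for antiproliferative activity, read by MTT assay, with a stated time of 72 h (on this read-out higher numbers stand for weaker inhibition and lower numbers for stronger inhibition), compound 1 `COc1ncc(-c2ccc3c(c2)N(c2ccc(C)cc2)C(=O)CO3)cc1NS(=O)(=O)c1ccc(F)cc1` gives 15400 nM, the lower of the two numbers measured so far. Going by the values given here, the only measured neighbour, compound 2 `COc1ncc(-c2ccc3c(c2)NC(=O)CO3)cc1NS(=O)(=O)c1ccc(F)cc1`, gives 32300 nM. Hydrogen in place of 4-methylphenyl on an amide-type nitrogen in a ring thus produces a 2.1-fold higher number from compound 1 to compound 2 (0.32 log units; beyond the scatter), a modest step.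

Compound 3 `Cc1ccc(N2C(=O)COc3ccc(-c4cnc(Cl)c(NS(=O)(=O)c5ccc(F)cc5)c4)cc32)cc1` keeps the 4-methylphenyl group and differs elsewhere, with chloro in place of methoxy on an aromatic carbon. This carbon belongs to a six-membered aromatic ring with 1 nitrogen, and the new group sits next to the ring nitrogen and ortho to a ((4-fluorophenyl)sulfonyl)amino group.

Among the compounds with values here, no measured step tests this exchange directly. Within the data shown here, the single step available concerns another place, and its size, a 2.1-fold higher number from compound 1 to compound 2 (0.32 log units; beyond the scatter), is the only guide, for the loss of a whole 4-methylphenyl group. No step beyond the scatter is therefore expected in this assay, in either direction, although this expectation is loosely founded.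

Compound 3 is estimated at 18000 nM, with an expected range from 6000 nM to 50000 nM. This estimate means an expected 1.2-fold higher number from compound 1 to compound 3 (0.07 log units; within the scatter).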

Compound 3, half-maximal inhibitory concentration: 32600 nM
For compound 3 the middle estimate is 1.8-fold (0.26 log units) below the measured one, within the range that was stated.
By their numbers in this assay, from the lowest: compound 1; then compounds 2 and 3 (each within the scatter of the next).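

Chloro in place of methoxy on the aromatic carbon next to the ring nitrogen gives a 2.1-fold higher number from compound 1 to compound 3 (0.33 log units; beyond the scatter) in this assay, which is the first measured sign that this position affects the read-out. The change is small in atoms, with one chlorine entering where one carbon and one oxygen leave, yet this modest step is of the same printed size as a 2.1-fold higher number from compound 1 to compound 2 (0.32 log units; beyond the scatter), where a whole 4-methylphenyl group is lost from the ring nitrogen of the amide type. Within this pair, methoxy goes with the lower number and chloro with the higher one, but no measurement available gives a reason for this step.

The compounds shown leave open how other groups on this carbon would read, such as an amine, a hydroxy group or the longer ethoxy chain, and so whether the step reflects something particular to methoxy or to chloro. They also leave open whether the same exchange would produce a step of this size in compound 2, which carries hydrogen in place of the 4-methylphenyl group.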